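The source may report more compounds than this note shows. Statements on the series, on what has been measured and on what is new or still open speak of the compounds shown alone.

Measured compounds:
compound 1 `Cc1ccc(C2CNC(=O)N2S(=O)(=O)c2ccc3c(c2)CCC3)cc1`, 90300 nM
compound 2 `Cc1ccc(S(=O)(=O)N2C(=O)NCC2c2ccc(Br)cc2)cc1`, 67000 nM

In a functional assay on A549 cells (Homo sapiens) for cytotoxicity (on this read-out higher numbers stand for weaker inhibition and lower numbers for stronger inhibition), compound 1 gives 90300 nM, the highest of the two numbers in hand. Its nearest neighbour is compound 2, whose value of 67000 nM is within the scatter of that of compound 1, so the two compounds cannot be ranked against each other on this read-out.

The step under study leads from compound 1 to compound 3 `O=C1NCC(c2ccc(Cl)cc2)N1S(=O)(=O)c1ccc2c(c1)CCC2`, which has not yet been measured in this assay. The change is chloro in place of methyl on an aromatic carbon. Going by the values given here, no step between measured compounds is available here, and compound 2 shares no single-point difference with either of them.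

Given the modest size of the change and the closeness of the two known values, compound 3 is expected to show a step of a 1.1-fold lower number from compound 1 to compound 3 (0.05 log units; within the scatter), essentially none beyond the scatter. Compound 3 is thus estimated at 80000 nM, within a range of 35000 nM to 180000 nM.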

Compound 3, half-maximal inhibitory concentration: > 265000 nM
Compound 3 was reported as a limit (the forecaster's own chance of this, stated with the estimate: 20%); middle value at least 3.3-fold (0.52 log units) from the limit.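

Placing chloro instead of methyl on the aromatic carbon para to a large group gives an at least 2.9-fold higher number from compound 1 to compound 3 (0.46 log units; beyond the scatter) in this assay, so the read-out responds to this single exchange of one heavy atom, something the earlier values could not show. Going by these compounds alone, this is the first step in the set that can be read at a single position, and it runs towards weaker inhibition. Compound 3 is reported only as a limit, > 265000 nM, so this step has a known lower bound but no known upper bound: the limit of > 265000 nM in this assay, at which 1 of the 3 values shown sits.

From the compounds shown here alone, it remains open whether a hydrogen, a methoxy group or a carboxylic acid on this carbon would give a value closer to that of compound 1 or to the limit of compound 3. Going by these compounds, whether the 4-methylphenyl to 4-chlorophenyl exchange acts in the same direction on any other core also remains open.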